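The compounds below may be only part of what the source reports. "The series", "measured", "known", "first", "only" and "open" are said of these compounds alone.

Measured compounds:
Compound 1 `COc1ccc2nc(C)cc(OCC(=O)Nc3cc(C)c(OC)c(C)c3)c2c1` — in a toxicity assay on HepG2 cells (Homo sapiens) for inhibition, read by CellTiter-Glo, with a stated time of 48 h (on this read-out lower numbers stand for stronger inhibition and higher numbers for weaker inhibition), compound 1 gives 7940 nM.
Compound 2 `COc1ccc2nc(C)cc(OCC(=O)Nc3cc(C)c(F)c(C)c3)c2c1` — in this assay compound 2 gives only a limit of the assay, > 100000 nM.

Compound 2 thus stands at the limit rather than at a number. Among the compounds with values here, the only measured step, an at least 12-fold higher number from compound 1 to compound 2 (1.10 log units; beyond the scatter), shows that (the limit of > 100000 nM in this assay, at which 1 of the 2 values shown sits). Compound 3 `COc1ccc2nc(C)cc(OCC(=O)Nc3c(C)cncc3C)c2c1` differs from compound 2 by 3,5-dimethylpyridin-4-yl in place of 4-fluoro-3,5-dimethylphenyl on an amide-type nitrogen. Within the data shown here, no measured step covers this kind of change, so the only guide is that compound 2 already sits at the limit of the assay, and nothing measured points to a recovery of inhibition. Compound 3 is therefore expected to remain a weak inhibitor, with an estimated step of a number no higher from compound 2 to compound 3 (the limit leaves the size open). The estimate for compound 3 in this assay is 100000 nM, within a range from 20000 nM to 500000 nM, and a further limit-only result is considered likely.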

Compound 3, half-maximal inhibitory concentration: 12600 nM
The estimate for compound 3 lay 7.9-fold (0.90 log units) above the measured number; the measured number lies below the stated range.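

Putting 3,5-dimethylpyridin-4-yl in place of 4-fluoro-3,5-dimethylphenyl on the amide-type nitrogen restores a measurable inhibition in this assay, with an at least 7.9-fold lower number from compound 2 to compound 3 (0.89 log units; beyond the scatter). The earlier step had shown only a move towards weaker inhibition, whereas this one shows that a change to the group at this place can also move the read-out towards stronger inhibition. The true size of the new step stays unknown, as it starts from a limit and not from a number: the limit of > 100000 nM in this assay, at which 1 of the 3 values shown sits.

The compounds shown do not separate the effect of the ring nitrogen from that of losing the fluorine, as both changes arrive together in compound 3. They also leave open how a 4-amino-3,5-dimethylphenyl group on the same nitrogen would read out.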